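A few compounds are considered here, and "the series" means these few. Any claim that something is new, unique, unknown or untested is made for them only; others in the source may bear on it.

Compound 1 `COc1ncnc2c1c(-c1ccsc1)cn2[C@@H]1O[C@H](CO)[C@@H](O)[C@H]1O`; compound 2 `COc1ncnc2c1c(-c1ccoc1)cn2[C@@H]1O[C@H](CO)[C@@H](O)[C@H]1O`; compound 3 `Cc1ncnc2c1c(-c1ccoc1)cn2[C@@H]1O[C@H](CO)[C@@H](O)[C@H]1O`; compound 4 `COc1ncnc2c1c(-c1cccs1)cn2[C@@H]1O[C@H](CO)[C@@H](O)[C@H]1O`, not yet measured.

In a functional assay on CCRF-CEM cells (Homo sapiens), read by MTT assay, with a stated time of 72 h (a higher number here means a weaker inhibitor, a lower number a stronger inhibitor), compound 1 gives 2570 nM. In this assay compound 2 gives 110 nM. Compound 3 reaches only a limit of this assay, > 20000 nM, the point marked by the limit of > 20000 nM in this assay, at which 1 of the 3 values shown sits. Among the two numbers, compound 2 stands lowest; its nearest neighbour is compound 1, separated by a 23-fold lower number from compound 1 to compound 2 (1.37 log units; beyond the scatter). The other step, an at least 180-fold higher number from compound 2 to compound 3 (2.25 log units; beyond the scatter), ends at the limit rather than at a number.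

Compound 4 differs from compound 2 by thiophen-2-yl in place of furan-3-yl on an aromatic carbon. The measured step that bears on this is a 23-fold lower number from compound 1 to compound 2 (1.37 log units; beyond the scatter), a large change in which a sulfur-bearing ring gave way to an oxygen-bearing one. The change to compound 4 brings a sulfur-bearing ring back, so the expectation is a step in the opposite direction, towards a higher number in this assay and beyond the scatter. Going by the values given here, no measured pair shows thiophen-2-yl, so the size of this step carries added uncertainty.

Compound 4 is therefore expected to give about 1500 nM, within 300 nM to 8000 nM. The expected step is a 14-fold higher number from compound 2 to compound 4 (1.13 log units; beyond the scatter).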

Compound 4, half-maximal inhibitory concentration: 90 nM
Compound 4: middle estimate off by 17-fold (1.22 log units), on the high side; the measured number lies below the stated range.
By their numbers in this assay, from the lowest: compounds 4 and 2 (each within the scatter of the next); then compound 1. At a limit, above all of these: compound 3.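

Read in this assay the result shows that a sulfur-bearing ring on this aromatic carbon does not by itself go with the weaker number of compound 1: thiophen-2-yl in compound 4 and furan-3-yl in compound 2 cannot be told apart (a 1.2-fold lower number from compound 2 to compound 4 (0.09 log units; within the scatter)). The large step between the two thiophenes (a 29-fold lower number from compound 1 to compound 4 (1.46 log units; beyond the scatter)) involves only the ring carbon through which the same ring is joined to the core, so the earlier step from thiophen-3-yl to furan-3-yl can no longer be read as a simple exchange of sulfur for oxygen. Nothing given here accounts for these differences.

The compounds shown leave open what furan-2-yl would give on this carbon, which would show whether the oxygen-bearing ring follows the same dependence on its point of attachment as the thiophenes. They also leave open whether the thiophen-2-yl series would keep its number with an amine or an ethoxy group in place of the methoxy group.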